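Cyclopropyloxy in place of cyclopropylmethyl on the shared core

A few compounds are considered here, and "the series" means these few. Any claim that something is new, unique, unknown or untested is made for them only; others in the source may bear on it.

Measured so far:
compound 1 `C=CCc1ccccc1OCC1=NCCN1` — 61.7 nM
compound 2 `c1ccc(OCC2=NCCN2)c(CC2CC2)c1` — 234 nM

In an assay on isolated protein for agonist activity at Alpha-2C adrenergic receptor (Homo sapiens) (on this read-out higher numbers stand for an effect only at larger amounts of compound and lower numbers for an effect already at smaller amounts), compound 2 stands at the higher of the two numbers, compound 1 at the lower. For the measured compounds named here, the one measured step is a 3.8-fold higher number from compound 1 to compound 2 (0.58 log units; beyond the scatter). Compound 3 `c1ccc(OC2CC2)c(OCC2=NCCN2)c1` differs from compound 2 by cyclopropyloxy in place of cyclopropylmethyl on an aromatic carbon. That measured step concerns a different change on the saturated chain carbon and does not bear on this exchange. With nothing to draw on, no step beyond the scatter is expected, so the estimated step is a 1.1-fold higher number from compound 2 to compound 3 (0.03 log units; within the scatter). Compound 3 is therefore expected at 250 nM, within a range from 60 nM to 1000 nM.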

Compound 3, half-maximal effective concentration: 1000 nM
Estimate against measurement, compound 3: 4.0-fold (0.60 log units) below, within the range that was stated.
By their numbers in this assay, from the lowest: compound 1; then compound 2; then compound 3.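

In this assay, the exchange of cyclopropylmethyl for cyclopropyloxy on this aromatic carbon gives a 4.3-fold higher number from compound 2 to compound 3 (0.63 log units; beyond the scatter), although both groups carry the same three-membered carbon ring. The exchange adds an oxygen and a hydrogen-bond acceptor to the group. Set against allyl, cyclopropyloxy gives a 16-fold higher number from compound 1 to compound 3 (1.21 log units; beyond the scatter), the largest step among these three compounds. Nothing available explains these steps. As far as these compounds go, whether an amine or a longer carbon chain at this place would give a number nearer compound 1 or compound 3 stays open.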